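Inverting a Cyclopropane Stereocentre in a Fatty Acid Receptor Agonist

The compounds below may be only part of what the source reports. "The series", "measured", "known", "first", "only" and "open" are said of these compounds alone.

Within the data shown here, compound 2 `Cc1nn(-c2ccccn2)c2cc(-c3ccc([C@H]4C[C@H]4C(=O)O)cc3)ccc12` stands highest of the two numbers measured so far in a functional assay on cells for agonist activity at Free fatty acid receptor 1 (Mus musculus), read by FLIPR and calcium flux, with a stated time of 5 min; on this read-out lower numbers stand for an effect already at smaller amounts and higher numbers for an effect only at larger amounts of compound: compound 2 gives 19000 nM. Its nearest neighbour is compound 1 `Cc1nn(-c2ccccn2)c2cc(-c3ccc(CCCC(=O)O)cc3)ccc12`, which in this assay gives 2100 nM. Among the measured compounds shown here, the only measured step, a 9.0-fold higher number from compound 1 to compound 2 (0.96 log units; beyond the scatter), concerns the exchange of the open chain for the ring and not a change of configuration. Compound 3 `Cc1nn(-c2ccccn2)c2cc(-c3ccc([C@@H]4C[C@H]4C(=O)O)cc3)ccc12` is related to compound 2 by the two compounds have the same atoms and bonds and differ only in configuration as drawn: 1 of 2 stereo elements differ; a stereocentre at a saturated ring carbon is drawn S in compound 2 and R in compound 3. For the measured compounds named here, no measured step bears directly on such an inversion; the step from compound 1 to compound 2 shows only that the ring-bearing acid sits well behind the chain acid, leaving open whether the other configuration recovers part of that loss. Because compound 1 reaches 2100 nM, a somewhat lower number than that of compound 2 is expected for compound 3, as a 2.7-fold lower number from compound 2 to compound 3 (0.43 log units; beyond the scatter), with wide uncertainty in either direction. Compound 3 is estimated at 7000 nM, within a range from 1500 nM to 30000 nM.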

Compound 3, half-maximal effective concentration: > 100000 nM
Compound 3: a limit, no number (the forecaster's own chance of this, stated with the estimate: 10%); middle value at least 14-fold (1.15 log units) away from the limit.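

Compound 3 reads in this assay as a limit and not as a number: the limit of > 100000 nM in this assay, at which 1 of the 3 values shown sits.

Even with that limit, the step shows what the earlier compounds could not: the configuration at this saturated ring carbon is not neutral, with an at least 5.2-fold higher number from compound 2 to compound 3 (0.72 log units; beyond the scatter), and this step can be attributed to configuration alone, because nothing else separates the two compounds: the fact that compounds 2 and 3 differ only in the configuration as drawn

Measured against the open 3-carboxypropyl chain, the gap widens to an at least 47-fold higher number from compound 1 to compound 3 (1.67 log units; beyond the scatter), so the other configuration at this carbon recovers none of the ground lost on going from the chain to the ring and instead adds to that loss.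

As far as these compounds go, how far compound 3 lies past its limit stays open, as does the outcome of inverting the second stereocentre of the cyclopropane ring, alone or together with the first. Also open, from the compounds shown here alone, is whether a 2-carboxycyclobutyl group in place of the 2-carboxycyclopropyl group, or a tetrazole in place of the carboxylic acid, would follow the same dependence on configuration or would come closer to the open chain of compound 1.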